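The compounds below may be only part of what the source reports. "The series", "measured", "known", "first", "only" and "open" are said of these compounds alone.

Three compounds have been measured in an assay for inhibition of Thromboxane-A synthase (Homo sapiens), using microsomes; a higher number here means a weaker inhibitor, a lower number a stronger inhibitor:

compound 1 `N#Cc1ccc(C2OCC(C/C=C\CCC(=O)O)C(c3cccnc3)O2)cc1` gives 24 nM
compound 2 `O=C(O)CC/C=C\CC1COC(c2ccc([N+](=O)[O-])cc2)OC1c1cccnc1` gives 39 nM
compound 3 `COc1ccc(OC(C)(C)C2OCC(C/C=C\CCC(=O)O)C(c3cccnc3)O2)cc1` gives 41 nM

Compound 3 stands among these three without separating from either of the others: its number and that of compound 2 lie within the scatter of each other, and the same holds for compound 3 against compound 1. The three share one core and differ only in the group that hangs from it.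

Compound 4 `COc1ccccc1OC(C)(C)C1OCC(C/C=C\CCC(=O)O)C(c2cccnc2)O1` is the next compound to be measured in this assay. It differs from compound 3 in one place: 2-methoxyphenyl in place of 4-methoxyphenyl on an oxygen on a saturated carbon.

Going by the values given here, only one step between measured compounds is available, and it concerns a different position: a 1.6-fold higher number from compound 1 to compound 2 (0.21 log units; within the scatter). That step does not involve the methoxyphenyl group at all, so nothing measured bears directly on the change from compound 3 to compound 4. Among the compounds with values here, the one step that exists stayed within the scatter, and the three measured numbers as a whole do not separate from one another. On that basis the step from compound 3 to compound 4 in this assay is expected to remain within the scatter, with no direction favoured: a 1.1-fold higher number from compound 3 to compound 4 (0.04 log units; within the scatter). Compound 4 is therefore estimated at 45 nM, with a range from 15 nM to 140 nM.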

Compound 4, half-maximal inhibitory concentration: 60 nM
Beside the measured number, compound 4's estimate is 1.3-fold (0.12 log units) below it; low and high end bracket the measured number.
By their numbers in this assay, from the lowest: compounds 1, 2, 3 and 4 (each within the scatter of the next, the first and the last beyond it).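

In this assay, going by these compounds alone, the exchange of 4-methoxyphenyl for 2-methoxyphenyl on an oxygen on a saturated carbon gives a 1.5-fold higher number from compound 3 to compound 4 (0.17 log units; within the scatter) and so supplies the first measured step at this position. The two groups have the same atoms, joined differently, and the same counts of heavy atoms and hydrogen-bond acceptors, so this pair isolates the place of the methoxy group on the ring, and here that difference does not separate the two compounds. No evidence is available that would explain this result.

The compounds shown leave open whether a group other than methoxy on that ring, such as an amine, a hydroxyl or a chlorine, would also stay within the scatter of compound 3. They also leave open how a phenyl group with no methoxy group at all would read on that oxygen, and whether a longer chain on the saturated carbon would keep the number in the same range.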